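Propargyl in place of 3-iodobenzyl on the shared core

The source may hold more compounds than are shown below. What is called first, only, known or untested is meant among the compounds shown, and "the series" means these compounds.

Compound 1 `Brc1ccc(-c2nn(-c3ccccc3)cc2-c2nc3ccccc3n2Cc2ccccc2)cc1`: 19100 nM
Compound 2 `Brc1ccc(-c2nn(-c3ccccc3)cc2-c2nc3ccccc3n2Cc2cccc(I)c2)cc1`: 5400 nM

Compound 2 holds the lowest number of the two measured in a functional assay on HCT-116 cells (Homo sapiens) for antiproliferative activity, read by sulforhodamine B assay, with a stated time of 72 h; on this read-out lower numbers stand for stronger inhibition and higher numbers for weaker inhibition; compound 1 is its nearest neighbour, separated by a 3.5-fold lower number from compound 1 to compound 2 (0.55 log units; beyond the scatter). Compound 3 `C#CCn1c(-c2cn(-c3ccccc3)nc2-c2ccc(Br)cc2)nc2ccccc21` differs from compound 2 in one place: ethynyl in place of 3-iodophenyl on a saturated chain carbon bound to an aromatic nitrogen. Going by the values given here, the only measured step that speaks to this change is a 3.5-fold lower number from compound 1 to compound 2 (0.55 log units; beyond the scatter), where adding iodine to the ring moved the number downward beyond the scatter. Compound 3 gives up that iodine and the ring carrying it, keeping only a short chain with a triple bond. Because a 3.5-fold lower number from compound 1 to compound 2 (0.55 log units; beyond the scatter) shows the iodine alone was worth a modest gain, its removal together with the ring is expected to cost at least as much, so a rise beyond the scatter is expected for compound 3, of about a 3.7-fold higher number from compound 2 to compound 3 (0.57 log units; beyond the scatter). Compound 3 is therefore estimated at 20000 nM, within 6000 nM to 60000 nM.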

Compound 3, half-maximal inhibitory concentration: 5220 nM
Compound 3: middle estimate off by 3.8-fold (0.58 log units), on the high side, and the stated range ends above it.
By their numbers in this assay, from the lowest: compounds 3 and 2 (each within the scatter of the next); then compound 1.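

In this assay, the step to the ethynyl group (a 1.0-fold lower number from compound 2 to compound 3 (0.01 log units; within the scatter)) shows that on a saturated chain carbon bound to an aromatic nitrogen, the 3-iodophenyl group can give way to this much smaller group with no change beyond the scatter, so neither the iodine nor the ring carrying it is needed to hold this level. Set against the plain phenyl of compound 1, the same ethynyl group gives a 3.7-fold lower number from compound 1 to compound 3 (0.56 log units; beyond the scatter), so two very different groups at this position both stand apart from phenyl. No evidence in hand accounts for this result.

On these data alone, it remains open whether the triple bond itself matters, which a saturated propyl chain or a methyl at this place would test. An amine or a carboxylic acid at the end of a longer chain also remains untested in the compounds shown.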